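Chloro to cyclopropylcarbonyl: expected maximal plasma concentration

A few compounds are considered here, and "the series" means these few. Any claim that something is new, unique, unknown or untested is made for them only; others in the source may bear on it.

Measured in an in vivo ADME assay on the whole organism (plasma) for pharmacokinetics, with Rattus norvegicus as the target, at a dose of 50 mg/kg by the oral route; a lower number here means less compound in the circulation, a higher number more compound in the circulation at the dose given:
Compound 1 `CC(=O)OCc1c(C)cc(C)c(NC(=O)c2sccc2S(=O)(=O)Nc2onc(C)c2Cl)c1C`: 7420 nM
Compound 2 `Cc1cc(C)c(NC(=O)c2sccc2S(=O)(=O)Nc2onc(C)c2Cl)c(Cl)c1`: 103000 nM

Compound 2 stands highest of the two, and compound 1 lies lower by more than the scatter. Compound 3 `Cc1cc(C)c(NC(=O)c2sccc2S(=O)(=O)Nc2onc(C)c2Cl)c(C(=O)C2CC2)c1` keeps the shared core and differs from compound 2 in one place: cyclopropylcarbonyl in place of chloro on an aromatic carbon, ortho to a large group (cyclopropylcarbonyl in place of chloro on an aromatic carbon). Within the data shown here, no measured pair shows this change alone, so the expectation rests on little. Among the measured compounds shown here, a step downward in this assay, probably beyond the scatter, is expected: compound 2 at 103000 nM is the top of only two values, and the sole other measured compound, compound 1, gives 7420 nM. The estimated change is a 3.7-fold lower number from compound 2 to compound 3 (0.57 log units; beyond the scatter). For compound 3 the estimate is 28000 nM, with an expected range of 7000 nM to 90000 nM.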

Compound 3, maximal plasma concentration: 108000 nM
Estimate against measurement, compound 3: 3.9-fold (0.59 log units) below; the measured number lies above the stated range.
By their numbers in this assay, from the lowest: compound 1; then compounds 2 and 3 (each within the scatter of the next).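

In this assay the exchange of chloro for cyclopropylcarbonyl on this aromatic carbon, ortho to a large group, gives a 1.0-fold higher number from compound 2 to compound 3 (0.02 log units; within the scatter) and so leaves the read-out within the scatter. In this assay this position therefore takes a group of 5 heavy atoms, with a three-membered ring and a carbonyl, in place of a single chlorine, with no step beyond the scatter. Among these compounds, nothing measured so far accounts for this result and the finding rests on this single pair.

Open, on these data alone, is whether an amine, a carboxylic acid or a longer chain on this aromatic carbon would keep the read-out within the scatter of compound 2 and compound 3. Also open, as far as these compounds go, is how compound 1 relates to this position, as it differs from compound 2 in more than one place.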